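The source may hold more compounds than are shown below. What is called first, only, known or untested is meant among the compounds shown, and "the series" means these compounds.

Measured compounds in an assay on cells for displacement of a labelled ligand from Glucagon receptor (Homo sapiens), in the presence of a further agent that is not named here; a higher number here means a weaker inhibitor, a lower number a stronger inhibitor:

compound 1, `CCCC(Oc1ccc(-n2cc(C(=O)N(C)C)cn2)cc1)c1ccc(C(=O)NCCC(=O)O)cc1`, gives 6500 nM
compound 2, `CCCC(Oc1ccc(-n2cc(C(F)(F)F)c(C)n2)cc1)c1ccc(C(=O)NCCC(=O)O)cc1`, gives 1100 nM
compound 3, `CCC(Oc1ccc(-n2cc(C(F)(F)F)cn2)cc1)c1ccc(C(=O)NCCC(=O)O)cc1`, gives 1400 nM

Compound 2 has the lowest number of the three in this assay. Compound 3 sits next to it, within the usual scatter, so no order between those two can be claimed; compound 1 lies furthest away, beyond the scatter.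

The next compound, compound 4, `CCCC(Oc1ccc(-n2cc3c(n2)CCCC3)cc1)c1ccc(C(=O)NCCC(=O)O)cc1`, is not yet measured. It differs from compound 2 in one place: a group of 9 heavy atoms (7 carbon, 2 nitrogen; one five-membered aromatic ring with 2 hetero atoms, one six-membered non-aromatic ring of carbon only) in place of a group of 10 heavy atoms (5 carbon, 2 nitrogen, 3 fluorine; one five-membered aromatic ring with 2 hetero atoms), on an aromatic carbon. Among the compounds with values here, the only measured step that concerns this same position is the one from compound 1 to compound 2, a 5.9-fold lower number from compound 1 to compound 2 (0.77 log units; beyond the scatter), which exchanged a dimethylcarbamoyl-bearing pyrazole for the methyl- and trifluoromethyl-bearing one and was modest. Within the data shown here, it shows that the substituent pattern on this five-membered ring can move the number, but no measured compound carries a fused six-membered non-aromatic ring there, so the direction for compound 4 rests on a single data point. With the trifluoromethyl group gone, a drift toward the weaker side seems the more likely outcome, without confidence that it will leave the scatter.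

Compound 4 is therefore expected to give about 2500 nM in this assay, within 800 nM to 8000 nM, an expected step of a 2.3-fold higher number from compound 2 to compound 4 (0.36 log units; beyond the scatter).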

Compound 4, inhibition constant: 690 nM
Compound 4: the middle estimate sits 3.6-fold (0.56 log units) above what was measured; the measured number lies below the stated range.
By their numbers in this assay, from the lowest: compounds 4, 2 and 3 (each within the scatter of the next, the first and the last beyond it); then compound 1.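

In this assay, the group with a six-membered non-aromatic ring of carbon only fused to the five-membered aromatic ring contains no fluorine, yet the step stays within the scatter (a 1.6-fold lower number from compound 2 to compound 4 (0.20 log units; within the scatter)), so among the compounds shown, trifluoromethyl is not required at this position on the shared core. The same group also gives a step beyond the scatter against the dimethylcarbamoyl-bearing group (a 9.4-fold lower number from compound 1 to compound 4 (0.97 log units; beyond the scatter)), so two different groups, one fused and one carrying methyl and trifluoromethyl, both have lower numbers than compound 1, and no order can be claimed between them. Nothing available explains why these groups compare as they do.

Still open, going by these compounds, is whether the fused non-aromatic ring itself matters, or whether simple alkyl substituents such as ethyl or isopropyl on the five-membered aromatic ring would give a number in the same range as compound 4. Also open, on these data alone, is how a nitrile, an amine or a hydroxyl on that ring or on the fused ring would behave in this assay, since the only substituents compared so far are dimethylcarbamoyl, methyl with trifluoromethyl, and the fused carbon ring.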